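This account rests on a few compounds, and the source may have more. Where it says the series, first, only, none or still open, it means among the compounds named here.

Measured so far:
compound 1 `Cn1c(=O)c(=O)n(C2CCCC2)c2nc(N/N=C/c3ccc(C(F)(F)F)cc3)ncc21`, with 23600 nM in a functional assay on PC-3 cells (Homo sapiens) for antiproliferative activity, read by MTT assay; a lower number here means a stronger inhibitor, a higher number a weaker inhibitor
compound 2 `Cc1cc(C)c(/C=N/Nc2ncc3c(n2)n(C2CCCC2)c(=O)c(=O)n3C)c(C)c1`, with 13900 nM in this assay
compound 3 `Cn1c(=O)c(=O)n(C2CCCC2)c2nc(N/N=C/c3cccc([N+](=O)[O-])c3)ncc21`, with 20300 nM in this assay

All three compounds share one core and differ only in the aromatic ring attached to the carbon with a double bond to nitrogen. Their numbers lie close together: the step of a 1.2-fold lower number from compound 1 to compound 3 (0.07 log units; within the scatter) and the step of a 1.5-fold higher number from compound 2 to compound 3 (0.16 log units; within the scatter) are both within the scatter, so compound 3 cannot be ranked against compound 1 or compound 2 in this assay. The remaining step, a 1.7-fold lower number from compound 1 to compound 2 (0.23 log units; within the scatter), is within the scatter as well.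

Compound 4 `Cn1c(=O)c(=O)n(C2CCCC2)c2nc(N/N=C/c3ccccc3Cl)ncc21` has not been measured. It differs from compound 3 in one place: 2-chlorophenyl in place of 3-nitrophenyl on a carbon with a double bond to nitrogen. Every step seen so far is a swap of this same aromatic ring, and none of them moved the number beyond the scatter. On that basis, the step of a 1.1-fold lower number from compound 3 to compound 4 (0.03 log units; within the scatter) is expected to stay within the scatter, with no clear direction. Compound 4 is therefore estimated to give about 19000 nM in this assay, with a range from 8000 nM to 45000 nM.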

Compound 4, half-maximal inhibitory concentration: 16300 nM
Beside the measured number, compound 4's estimate is 1.2-fold (0.07 log units) above it; low and high end bracket the measured number.
By their numbers in this assay, from the lowest: compounds 2, 4, 3 and 1 (each within the scatter of the next).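

In this assay, the 2-chlorophenyl ring brings a chlorine to this position and carries no hydrogen-bond acceptors, whereas the 3-nitrophenyl ring it replaces carries them, yet a 1.2-fold lower number from compound 3 to compound 4 (0.10 log units; within the scatter) is how small the result of that exchange is. The comparisons with the other two rings tell the same story, with a 1.2-fold higher number from compound 2 to compound 4 (0.07 log units; within the scatter) and a 1.4-fold lower number from compound 1 to compound 4 (0.16 log units; within the scatter) as the remaining steps, so a fourth aromatic ring on the carbon with a double bond to nitrogen has produced no step beyond the scatter, and the four compounds cannot be ranked against one another. Nothing available here accounts for this flat picture.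

On these data alone, all four compounds keep a phenyl ring with neutral substituents at this position, so it remains open whether a ring bearing an amine or a carboxylic acid, or a saturated carbon chain in place of the ring, would move the number beyond the scatter. The shared core is also the same throughout, which leaves open whether another group on it, such as a smaller ring in place of the cyclopentyl, would matter more than the aromatic ring does.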